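Furan for methoxyphenyl on a nitrooxy amide chalcone

The source may report more compounds than this note shows. Statements on the series, on what has been measured and on what is new or still open speak of the compounds shown alone.

The three measured compounds share one core and are read in a functional assay on the whole organism (strain albino) for inhibition, with Rattus norvegicus as the target, read by paw edema, with stated times of 30 min and 3 h, at a dose of 100 mg/kg by the oral route; on this read-out higher numbers stand for more inhibition at the one dose given (going by the name of the read-out) and lower numbers for less inhibition. Compound 1 `COc1ccc(/C=C/C(=O)c2ccc(NC(=O)CO[N+](=O)[O-])cc2)cc1` gives 53% in this assay. Compound 2 `O=C(CO[N+](=O)[O-])Nc1ccc(C(=O)/C=C/c2ccco2)cc1` carries furan-2-yl in place of 4-methoxyphenyl on a double-bonded chain carbon bound to a double-bonded chain carbon and gives 48% in this assay; the step of a number 5 percentage points lower from compound 1 to compound 2 (within the scatter). Compound 3 `COc1ccc(/C=C/C(=O)c2ccc(NC(=O)C(C)O[N+](=O)[O-])cc2)cc1` differs from compound 1 by methyl in place of hydrogen on a saturated chain carbon bound to a carbonyl carbon and an oxygen on an unsaturated carbon. In this assay compound 3 gives 50%; the step of a number 3 percentage points lower from compound 1 to compound 3 (within the scatter). The values of compound 2 and compound 3 lie close together, and no order can be read among the three.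

The unmeasured compound 4 `CC(O[N+](=O)[O-])C(=O)Nc1ccc(C(=O)/C=C/c2ccco2)cc1` differs from compound 3 by furan-2-yl in place of 4-methoxyphenyl on a double-bonded chain carbon bound to a double-bonded chain carbon. This is the same change that carries compound 1 to compound 2, made on the core of compound 3 rather than the core of compound 1; the two cores differ by methyl in place of hydrogen on a saturated chain carbon bound to a carbonyl carbon and an oxygen on an unsaturated carbon, and the place of the change reads the same in both cases. The step already seen is a number 5 percentage points lower from compound 1 to compound 2 (within the scatter).

Among the measured compounds shown here, the expectation for compound 4 in this assay rests on that one earlier step, since the step from compound 1 to compound 2 a number 5 percentage points lower from compound 1 to compound 2 (within the scatter) is the only measured instance of this change. Compound 4 is therefore expected to move by a number 5 percentage points lower from compound 3 to compound 4 (within the scatter) in this assay. Compound 4 is estimated at 45% in this assay, with a likely range from 35% to 55%.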

Compound 4, a percentage reported as inhibition, in the whole organism at one dose (the size of the read-out at that dose, not a potency): 54%
For compound 4 the middle estimate is 9 percentage points below the measured one; low and high end bracket the measured number.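

On the core of compound 3, furan-2-yl in place of 4-methoxyphenyl gives in this assay a step that reads a number 4 percentage points higher from compound 3 to compound 4 (within the scatter), and set beside the same change on the core of compound 1 it shows no difference that can be told from scatter: the same change on two cores in this assay, a number 5 percentage points lower (within the scatter) from compound 1 to compound 2 and a number 4 percentage points higher (within the scatter) from compound 3 to compound 4, 9 percentage points apart, within the scatter of two such steps

The methyl in place of hydrogen, carried from the core of compound 1 to the core of compound 2, gives a step that reads a number 6 percentage points higher from compound 2 to compound 4 (within the scatter), and it too stays level with its earlier counterpart: the same change on two cores in this assay, a number 3 percentage points lower (within the scatter) from compound 1 to compound 3 and a number 6 percentage points higher (within the scatter) from compound 2 to compound 4, 9 percentage points apart, within the scatter of two such steps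

So in these four compounds both changes carry from one core to the other without a step that stands out, but since every step lies within the scatter and the steps on the two cores point in opposite directions, this shows neither a shared effect of either change nor that the cores interact, only that one dose of this read-out resolves no difference among them.

The compounds shown leave open whether any group at this place would move the number beyond the scatter, for instance an amine or a carboxylic acid in the place of furan-2-yl and 4-methoxyphenyl. They also leave open what a longer chain in place of the methyl would do, and how these compounds would compare in potency, which a single dose cannot give.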